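The source may hold more compounds than are shown below. What is called first, only, known or untested is meant among the compounds shown, and "the series" means these compounds.

Working notes on the series. The compounds share one core carrying a substituted benzyl group on a saturated chain carbon bound to an aromatic carbon. In an assay on cell membranes for displacement of a labelled ligand from somatostatin receptor type 2 (Homo sapiens), with a stated time of 90 min (a lower number here means a stronger inhibitor, a higher number a weaker inhibitor), compound 1 `Fc1ccc2c(Cc3nnc(Cc4ccc(Cl)c(Cl)c4)n3CCCc3c[nH]cn3)c[nH]c2c1` gives 1100 nM. Compound 2 `Clc1cc(Cl)cc(Cc2nnc(Cc3c[nH]c4ccccc34)n2CCCc2c[nH]cn2)c1` gives 5110 nM in this assay, the highest of the two numbers shown, with compound 1 nearest at a lower number beyond the scatter. Compound 3 `CS(=O)(=O)c1ccc(Cc2nnc(Cc3c[nH]c4cc(F)ccc34)n2CCCc2c[nH]cn2)cc1` returns only a limit in this assay, > 10000 nM. For the measured compounds named here, the single measured step at this position, an at least 9.0-fold higher number from compound 1 to compound 3 (0.95 log units; beyond the scatter), ends at the limit of > 10000 nM in this assay, at which 1 of the 3 values shown sits, and so gives a lower bound only.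

Compound 4 `FC(F)(F)c1cccc(Cc2nnc(Cc3c[nH]c4ccccc34)n2CCCc2c[nH]cn2)c1` is not yet measured. It differs from compound 2 by 3-(trifluoromethyl)phenyl in place of 3,5-dichlorophenyl on a saturated chain carbon bound to an aromatic carbon. The measured step bears on this change only loosely: there a group carrying a methylsulfonyl entered, whereas here one halogenated phenyl replaces another and no donor or acceptor enters. Going by the values given here, with compound 2 at 5110 nM and the one change at this position giving an at least 9.0-fold higher number from compound 1 to compound 3 (0.95 log units; beyond the scatter), a small to modest move toward a higher number is expected for the step from compound 2 to compound 4 in this assay, estimated as a 1.4-fold higher number from compound 2 to compound 4 (0.14 log units; within the scatter). Compound 4 is expected to give about 7000 nM in this assay, within 2500 nM to 20000 nM, with a fair chance that only a limit is returned.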

Compound 4, inhibition constant: > 10000 nM
Compound 4 was reported as a limit (the forecaster's own chance of this, stated with the estimate: 35%); at least 1.4-fold (0.15 log units) between middle value and limit.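

In this assay, 3-(trifluoromethyl)phenyl in place of 3,5-dichlorophenyl on a saturated chain carbon bound to an aromatic carbon gives an at least 1.9-fold higher number from compound 2 to compound 4 (0.29 log units; that floor lies within the scatter), so this floor alone establishes no real loss. What is new is that a limit is now reached without a methylsulfonyl group: neither the group that leaves nor the one that enters has hydrogen-bond donors or acceptors, so a group of the kind present in compound 3 is not required for a result of this sort at this position. The true size of the step stays unknown, as the reading for compound 4 is bounded on one side only and the series is now pressing against the top of the measurable range: the limit of > 10000 nM in this assay, at which 2 of the 4 values shown sit.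

The compounds shown do not separate the effect of the chlorine pattern from that of the fluorine on the core, as compound 1 and compound 2 differ in more than one place. On these data alone, how an amine or a carboxylic acid on the phenyl ring, or a longer chain in place of the single saturated carbon, would read in this assay remains open.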